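Carboxy to hydroxymethyl on the amide substituent of compound 3

A few compounds are considered here, and "the series" means these few. Any claim that something is new, unique, unknown or untested is made for them only; others in the source may bear on it.

Compound 3 `CCn1c(C(=O)NC(C)C(=O)O)ccc1C(CC)(CC)c1ccc(OCCC(O)(CC)CC)c(C)c1` gives the lowest number of the three compounds measured, 66 nM in an assay on cells for agonist activity at vitamin D3 receptor (Homo sapiens), with a stated time of 96 h; on this read-out higher numbers stand for an effect only at larger amounts of compound and lower numbers for an effect already at smaller amounts. Compound 1 `CCn1c(C(=O)NCCN)ccc1C(CC)(CC)c1ccc(OCCC(O)(CC)CC)c(C)c1` gives 156 nM, and compound 2 `CCOc1ccc(NC(=O)c2ccc(C(CC)(CC)c3ccc(OCCC(O)(CC)CC)c(C)c3)n2CC)cc1` gives 1630 nM. The steps from compound 1 to compound 2 (a 10-fold higher number from compound 1 to compound 2 (1.02 log units; beyond the scatter)) and from compound 2 to compound 3 (a 25-fold lower number from compound 2 to compound 3 (1.39 log units; beyond the scatter)) show that the group on the amide nitrogen matters greatly, while the change from compound 1 to compound 3 (a 2.4-fold lower number from compound 1 to compound 3 (0.37 log units; beyond the scatter)) is modest. Compound 4 `CCn1c(C(=O)NC(C)CO)ccc1C(CC)(CC)c1ccc(OCCC(O)(CC)CC)c(C)c1` differs from compound 3 by hydroxymethyl in place of carboxy on a saturated chain carbon bound to an amide-type nitrogen and a saturated chain carbon. Both groups carry a donor and an acceptor, so a small step, toward a higher number, is expected: a 1.7-fold higher number from compound 3 to compound 4 (0.22 log units; within the scatter). Compound 4 is estimated at 110 nM, in a range from 40 nM to 300 nM.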

Compound 4, half-maximal effective concentration: 96 nM
Estimate against measurement, compound 4: 1.1-fold (0.06 log units) above, and the stated range covers the measured number.
By their numbers in this assay, from the lowest: compounds 3, 4 and 1 (each within the scatter of the next, the first and the last beyond it); then compound 2.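

In this assay the carboxy group on this saturated chain carbon can give way to hydroxymethyl with the difference staying within the scatter (a 1.5-fold higher number from compound 3 to compound 4 (0.16 log units; within the scatter)), so a carboxy group is not needed here for a number of this size. The 1-(hydroxymethyl)ethyl group likewise stays within the scatter of 2-aminoethyl (a 1.6-fold lower number from compound 1 to compound 4 (0.21 log units; within the scatter)) and keeps the large distance from 4-ethoxyphenyl (a 17-fold lower number from compound 2 to compound 4 (1.23 log units; beyond the scatter)). No evidence bears on the reason for this. From the compounds shown here alone, whether an aminomethyl or methoxymethyl group on this carbon would behave like hydroxymethyl remains open. So does the effect of a longer chain in place of the methyl on the same carbon.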